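The source may report more compounds than this note shows. Statements on the series, on what has been measured and on what is new or still open speak of the compounds shown alone.

In a functional assay, read by spectrophotometry, tested at 100 uM (a lower number here means a stronger inhibitor, a higher number a weaker inhibitor), compound 1 `Cc1ccc(/C=C/C(=O)c2cccc(NC(=O)c3cc(-c4ccncc4)n[nH]3)c2)cc1` gives 64600 nM and compound 2 `O=C(/C=C/c1ccco1)c1cccc(NC(=O)c2cc(-c3ccncc3)n[nH]2)c1` gives 72300 nM as its read-out, so the two cannot be told apart. Compound 3 `COc1cc(/C=C/C(=O)c2cccc(NC(=O)c3cc(-c4ccncc4)n[nH]3)c2)cc(OC)c1OC` differs from compound 2 in one place: 3,4,5-trimethoxyphenyl in place of furan-2-yl on a double-bonded chain carbon bound to a double-bonded chain carbon with 3,4,5-trimethoxyphenyl in place of furan-2-yl on a double-bonded chain carbon bound to a double-bonded chain carbon. Among the compounds with values here, only one measured step bears on this place, namely a 1.1-fold higher number from compound 1 to compound 2 (0.05 log units; within the scatter) when furan-2-yl stands in place of 4-methylphenyl. Within the data shown here, that step is small, but it is a single exchange, and no measured compound carries 3,4,5-trimethoxyphenyl. No step beyond the scatter is therefore expected in this assay in either direction. The expected change is a 1.2-fold lower number from compound 2 to compound 3 (0.08 log units; within the scatter) and no more. For compound 3 the estimated value is 60000 nM with an expected range from 25000 nM to 100000 nM.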

Compound 3, half-maximal inhibitory concentration: 52900 nM
The estimate for compound 3 lay 1.1-fold (0.05 log units) above the measured number; low and high end bracket the measured number.
By their numbers in this assay, from the lowest: compounds 3, 1 and 2 (each within the scatter of the next).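

In this assay, the position on a double-bonded chain carbon bound to a double-bonded chain carbon accepts 3,4,5-trimethoxyphenyl, with 12 heavy atoms and 3 hydrogen-bond acceptors, in place of furan-2-yl, with 5 heavy atoms and 1 hydrogen-bond acceptor, and this exchange gives a 1.4-fold lower number from compound 2 to compound 3 (0.14 log units; within the scatter). Exchanging 4-methylphenyl for the same group gives a 1.2-fold lower number from compound 1 to compound 3 (0.09 log units; within the scatter), so the earlier single step within the scatter now extends to a six-membered aromatic ring carrying three methoxy groups. No measurement at hand accounts for this result.

From the compounds shown here alone, it remains open whether any group at this position can move the number beyond the scatter, such as a carboxylic acid or a dimethylamino group. The compounds shown also leave open how changes to the shared core would affect the number.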